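Compound 3 at the end of the side chain

The source may hold more compounds than are shown below. What is called first, only, known or untested is meant among the compounds shown, and "the series" means these compounds.

Compound 1 `Cc1cccc(/C=C/[C@](C)(O)CC[C@@H]2[C@@]3(C)CCCC(C)(C)[C@@H]3CC[C@@]2(C)O)c1C` gives 3800 nM
Compound 2 `CC1(C)CCC[C@]2(C)[C@@H](CC[C@@](C)(O)/C=C/c3ccc(Cl)nc3)[C@](C)(O)CC[C@@H]12` gives 3280 nM

Both values come from a functional assay on A549 cells (Homo sapiens) for cytotoxicity, read by MTT assay, with a stated time of 48 h (a lower number here means a stronger inhibitor, a higher number a weaker inhibitor), and lie within the scatter of each other, so compound 2 cannot be set apart from compound 1. The unmeasured compound 3 `CC(C)(C)c1ccc(/C=C/[C@](C)(O)CC[C@@H]2[C@@]3(C)CCCC(C)(C)[C@@H]3CC[C@@]2(C)O)cc1` keeps the shared core and differs from compound 2 in one place. The change is 4-(tert-butyl)phenyl in place of 6-chloropyridin-3-yl on a double-bonded chain carbon bound to a double-bonded chain carbon and puts 4-(tert-butyl)phenyl in place of 6-chloropyridin-3-yl on a double-bonded chain carbon bound to a double-bonded chain carbon. Among the compounds with values here, one measured step bears on it at that same place, where 6-chloropyridin-3-yl stands in place of 2,3-dimethylphenyl: the data show a 1.2-fold lower number from compound 1 to compound 2 (0.06 log units; within the scatter) and nothing larger. Within the data shown here, no measured compound carries 4-(tert-butyl)phenyl, so the evidence is thin. Among the measured compounds shown here, with a 1.2-fold lower number from compound 1 to compound 2 (0.06 log units; within the scatter) as the only guide, no step beyond the scatter is expected in this assay in either direction. The estimate amounts to an expected 1.1-fold higher number from compound 2 to compound 3 (0.03 log units; within the scatter) for this change. Compound 3 is estimated at 3500 nM with 1800 nM to 7000 nM as its expected range.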

Compound 3, half-maximal inhibitory concentration: 45000 nM
The estimate for compound 3 lay 13-fold (1.11 log units) below the measured number; measured number outside the range, above it.
By their numbers in this assay, from the lowest: compounds 2 and 1 (each within the scatter of the next); then compound 3.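

In this assay this position proves not to be indifferent to the group it carries, although the first two compounds gave no sign of that. With 4-(tert-butyl)phenyl in place of 6-chloropyridin-3-yl on the double-bonded chain carbon the data show a 14-fold higher number from compound 2 to compound 3 (1.14 log units; beyond the scatter) and, with the same group in place of 2,3-dimethylphenyl, they show a 12-fold higher number from compound 1 to compound 3 (1.07 log units; beyond the scatter) as well. Both steps lie beyond the scatter and start from compounds that cannot be told apart, so the weaker number goes with the arrival of 4-(tert-butyl)phenyl whichever of the two earlier groups it replaces, and nothing available accounts for this.

It remains open whether the tert-butyl group alone carries this step, since a plain phenyl ring or a phenyl ring bearing a methyl, an amine or a carboxylic acid does not appear among these compounds. Within the data shown here, with only three groups at this one place, it is also open whether the numbers climb gradually with other groups or whether 4-(tert-butyl)phenyl stands alone.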